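The source may hold more compounds than are shown below. What is called first, only, known or untested is meant among the compounds shown, and "the series" means these compounds.

In a functional assay on MCF7 cells (Homo sapiens) for antiproliferative activity, read by sulforhodamine B assay, with a stated time of 48 h (a lower number here means a stronger inhibitor, a higher number a weaker inhibitor), compound 1 `Cc1ccc(OS(=O)(=O)c2ccc(N3CCN(C)C3=O)cc2)c(C)c1` gives 2500 nM, and compound 2 `CCCN1CCN(c2ccc(S(=O)(=O)Oc3ccc(C)cc3C)cc2)C1=O` gives 1500 nM. These two numbers are all that has been measured so far, and compound 2 stands level with compound 1, since a 1.7-fold lower number from compound 1 to compound 2 (0.22 log units; within the scatter) does not clear the usual scatter. The next compound, compound 3 `CCCN1CCN(c2ccc(S(=O)(=O)Oc3cccc(Cl)c3)cc2)C1=O`, keeps the rest of compound 2 and changes one group: 3-chlorophenyl in place of 2,4-dimethylphenyl on an oxygen. In words, 3-chlorophenyl sits in place of 2,4-dimethylphenyl on an oxygen, whose other neighbour is the sulfonyl sulfur. Going by the values given here, the single measured step, a 1.7-fold lower number from compound 1 to compound 2 (0.22 log units; within the scatter), was made elsewhere in the molecule, so it offers only a weak guide, and no measured pair tests this group. No clear direction can be expected in this assay, and the expected change, a 1.3-fold higher number from compound 2 to compound 3 (0.12 log units; within the scatter), is an estimate that stays modest. Compound 3 is expected at about 2000 nM, with an estimated range of 600 nM to 6500 nM.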

Compound 3, half-maximal inhibitory concentration: 380 nM
The estimate for compound 3 lay 5.3-fold (0.72 log units) above the measured number; the measured number lies below the stated range.
By their numbers in this assay, from the lowest: compound 3; then compounds 2 and 1 (each within the scatter of the next).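

Going by these compounds alone, changing the group on the oxygen whose other neighbour is the sulfonyl sulfur gives the first step to clear the scatter in this assay, with a 3.9-fold lower number from compound 2 to compound 3 (0.60 log units; beyond the scatter). Within the data shown here, the earlier change elsewhere in the molecule, with a 1.7-fold lower number from compound 1 to compound 2 (0.22 log units; within the scatter), stayed within the scatter, so this oxygen-bound aromatic group is the only place so far where a change is clearly visible in the numbers. Nothing measured here explains why 3-chlorophenyl gives the lower number.

This single swap removes both methyl groups and adds a chlorine, so it cannot show whether the step comes from losing the methyls, from gaining the chlorine, or from both. A plain phenyl group on the same oxygen, or a bromine in place of the chlorine, would help separate these possibilities.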